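This account rests on a few compounds, and the source may have more. Where it says the series, first, only, none or still open, it means among the compounds named here.

Measured so far in a functional assay on QGY7701 cells (Homo sapiens) for cytotoxicity, read by MTT assay, with a stated time of 24 h; on this read-out lower numbers stand for stronger inhibition and higher numbers for weaker inhibition:

compound 1 `C=CC1=C(C(=O)NCc2ccc(Cl)cc2)C(c2ccc(OC)cc2)OC1` – > 100000 nM
compound 2 `C=CC1=C(C(=O)Nc2ccccc2OC)C(c2ccc(OC)cc2)OC1` – > 100000 nM
compound 3 `C=CC1=C(C(=O)Nc2ccc(C)cc2)C(c2ccc(OC)cc2)OC1` – > 100000 nM

Each of these entries is a limit of this assay and not a number. For compound 3 the read-out is therefore a limit only, > 100000 nM, and the same holds for the two others, so nothing places compound 3 higher or lower than compound 1 or compound 2. The comparisons among the three are accordingly blank: a step that the two limits leave unreadable from compound 1 to compound 2, a step that the two limits leave unreadable from compound 1 to compound 3 and a step that the two limits leave unreadable from compound 2 to compound 3 all stay unreadable. The whole picture so far is the limit of > 100000 nM in this assay, at which 3 of the 3 values shown sit.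

Compound 4 `C=CC1=C(C(=O)NCC(C)C)C(c2ccc(OC)cc2)OC1` has not yet been run in this assay. It differs from compound 3 as follows: isobutyl in place of 4-methylphenyl on an amide-type nitrogen. Within the data shown here, of the steps measured, the one from compound 2 to compound 3 and the one from compound 1 to compound 3 concern the same amide-type nitrogen, but with both ends at a limit their size is not readable, so no direction can be taken from them. Given that compound 3 sits at > 100000 nM, the step to compound 4 is expected to be a number no higher from compound 3 to compound 4 (the limit leaves the size open), with the most likely outcome another limit. Compound 4 is therefore estimated at 100000 nM, in a range from 40000 nM to 300000 nM.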

Compound 4, half-maximal inhibitory concentration: > 100000 nM
Compound 4: no number, only a limit (the forecaster's own chance of this, stated with the estimate: 85%); the middle value lies on the limit itself.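

In this assay, among these compounds, compound 4 gives > 100000 nM, a limit and not a number, so no step between it and compound 1, compound 2 or compound 3 can be read. The compounds shown leave open whether any group on the amide-type nitrogen gives a measurable value, since the series sits at a single limit: the limit of > 100000 nM in this assay, at which 4 of the 4 values shown sit.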